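Swapping the ether's aryl group in a quinoline-linked aminophenol series

The source may hold more compounds than are shown below. What is called first, only, known or untested is meant among the compounds shown, and "the series" means these compounds.

Measured so far:
compound 1, `COc1cccc(CNCCCNc2ccnc3cc(-c4ccc(C(C)(C)C)cc4)ccc23)c1O`, 32000 nM
compound 2, `COc1cccc(CNCCCNc2ccnc3cc(Oc4ccc(F)cc4)ccc23)c1O`, 14500 nM

Among the measured compounds shown here, in a physicochemical assay for solubility, with a stated time of 18 h, at pH 7.4 (on this read-out lower numbers stand for lower solubility and higher numbers for higher solubility), compound 2 gives 14500 nM, the lowest of the two numbers so far; the nearest neighbour is compound 1 with 32000 nM, and the step of a 2.2-fold lower number from compound 1 to compound 2 (0.34 log units; beyond the scatter) lies beyond the scatter.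

Compound 3, `COc1ccccc1Oc1ccc2c(NCCCNCc3cccc(OC)c3O)ccnc2c1`, has not yet been measured in this assay. It differs from compound 2 in one place: 2-methoxyphenyl in place of 4-fluorophenyl on an oxygen on an aromatic ring. For the measured compounds named here, no measured step covers this particular swap. Going by the values given here, the only step available, a 2.2-fold lower number from compound 1 to compound 2 (0.34 log units; beyond the scatter), changed the group that hangs off the shared core and moved the number modestly; it shows that changes at this position can shift the read-out, but gives no direction for a methoxy in place of a fluorine.

With so little to lean on, a step of a 1.2-fold higher number from compound 2 to compound 3 (0.09 log units; within the scatter) is expected, most likely within the scatter or slightly upward. Compound 3 is therefore estimated at 18000 nM, with a range from 7000 nM to 45000 nM.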

Compound 3, solubility: 14500 nM
The estimate for compound 3 lay 1.2-fold (0.09 log units) above the measured number; measured number inside the range.
By their numbers in this assay, from the lowest: compounds 2 and 3 (each within the scatter of the next); then compound 1.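

In this assay, replacing 4-fluorophenyl with 2-methoxyphenyl on an oxygen on an aromatic ring gives no change at the digits printed from compound 2 to compound 3 (within the scatter) and so leaves the read-out unmoved, which shows that this position tolerates at least one change of aryl group without a measurable shift. The swap of 4-(tert-butyl)phenyl for 2-methoxyphenoxy on an aromatic carbon gives a 2.2-fold lower number from compound 1 to compound 3 (0.34 log units; beyond the scatter) and matches in size the earlier step, a 2.2-fold lower number from compound 1 to compound 2 (0.34 log units; beyond the scatter) so both phenoxy compounds now stand apart from compound 1 by the same margin, and neither goes against that small pattern. No independent measurement here explains why the two phenoxy groups read alike or why they differ from the 4-(tert-butyl)phenyl group.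

Each step away from compound 1 changes both the oxygen link and the group on the ring, so the compounds shown cannot tell which of the two accounts for the shift. On these data alone, it also remains open whether a group with a charge on that ring, such as an amine or a carboxylic acid, or a longer chain in its place, would move the number where fluorine and methoxy do not.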